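The compounds below may be only part of what the source reports. "The series", "measured", "known", "first", "only" and "open" are said of these compounds alone.

Measured in an ADME assay on a cell-free system (plasma, Mus musculus) for protein binding:
- Compound 1 `CNc1nccc(N2CC[C@H](NC(=O)Nc3cc(OC)cc(OC)c3)C2)n1`: 96.9%
- Compound 2 `CNc1nccc(N2CC[C@H](NC(=O)Nc3ccc(OC)cc3)C2)n1`: 82.1%
- Compound 3 `CNc1nccc(N2CC[C@H](NC(=O)Nc3ccc(C)c(Cl)c3)C2)n1`: 98.6%

Compound 3 has the smallest free share of the three, with 98.6%, while compound 1 gives 96.9%. Compound 4 `CNc1nccc(N2CC[C@H](NC(=O)Nc3cccc(OC)c3)C2)n1` has 3-methoxyphenyl in place of 3-chloro-4-methylphenyl on an amide-type nitrogen. The closest measured step is a 13-fold lower unbound fraction from compound 2 to compound 3 (1.11 log units; beyond the scatter), which is large and beyond the scatter. It swaps 3-chloro-4-methylphenyl for 4-methoxyphenyl, so the change to compound 4 resembles that step run backwards. A somewhat smaller move towards more free compound is therefore expected in this assay, and the estimated step is an 8.6-fold higher unbound fraction from compound 3 to compound 4 (0.93 log units; beyond the scatter). For compound 4 the expected value is 88%, with an estimated range from 75% to 95%.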

Compound 4, plasma protein binding: 91.6%
For compound 4 the middle estimate is 1.4-fold (0.15 log units) (unbound fraction) above the measured one; low and high end bracket the measured number.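

In this assay the swap from 4-methoxyphenyl to 3-methoxyphenyl on the amide-type nitrogen gives a 2.1-fold lower unbound fraction from compound 2 to compound 4 (0.33 log units; beyond the scatter) and so shows that where the methoxy group sits counts, not only that it is there. Hydrogen in place of one methoxy gives a 2.7-fold higher unbound fraction from compound 1 to compound 4 (0.43 log units; beyond the scatter) and shows that the second methoxy also counts. Replacing 3-chloro-4-methylphenyl with 3-methoxyphenyl gives a 6.0-fold higher unbound fraction from compound 3 to compound 4 (0.78 log units; beyond the scatter) and so the single methoxy does not match the chlorine and methyl pair. As far as these compounds go, whether an amine or a carboxylic acid on this ring would free still more compound stays open. Nothing measured here says what lies behind these shifts.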